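Notes on compound 4 ahead of its cytotoxicity measurement

The source may report more compounds than this note shows. Statements on the series, on what has been measured and on what is new or still open speak of the compounds shown alone.

Compound 1 `CC(C)Cc1ccc2c(NCCCNCc3ccco3)ccnc2c1`: 16000 nM
Compound 2 `COc1ccc(F)cc1CNCCCNc1ccnc2cc(Cc3cc(C)cc(C)c3)ccc12`: 940 nM
Compound 3 `Cc1cc(C)cc(Cc2ccc3c(NCCCNCc4ccco4)ccnc3c2)c1`: 6270 nM

In an ADME assay on HepG2 cells (Homo sapiens) for cytotoxicity, read by luminescence, CellTiter-Glo and ATP content, with a stated time of 72 h (a lower number here means that less compound is needed, a higher number that more compound is needed for the effect), compound 2 stands lowest of the three numbers. The nearest is compound 3, a 6.7-fold higher number from compound 2 to compound 3 (0.82 log units; beyond the scatter); the furthest is compound 1, whose step to compound 3 is a 2.6-fold lower number from compound 1 to compound 3 (0.41 log units; beyond the scatter).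

Compound 4 `COc1ccc(F)cc1CNCCCNc1ccnc2cc(-c3ccc(F)cc3)ccc12` differs from compound 2 in one place: 4-fluorophenyl in place of 3,5-dimethylbenzyl on an aromatic carbon. Among the compounds with values here, the only measured step at this carbon is a 2.6-fold lower number from compound 1 to compound 3 (0.41 log units; beyond the scatter), where 3,5-dimethylphenyl replaced isopropyl and the number fell modestly. The step of a 6.7-fold higher number from compound 2 to compound 3 (0.82 log units; beyond the scatter) lies at the other end of the chain and bears less on this change. Taking away the 3,5-dimethylbenzyl for 4-fluorophenyl is therefore expected to raise the number modestly, a 2.3-fold higher number from compound 2 to compound 4 (0.37 log units; beyond the scatter), though this rests on one step. Compound 4 is expected at 2200 nM, in the range 700 nM to 7000 nM.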

Compound 4, half-maximal effective concentration: 770 nM
The estimate for compound 4 lay 2.9-fold (0.46 log units) above the measured number; the range from low to high includes it.
By their numbers in this assay, from the lowest: compounds 4 and 2 (each within the scatter of the next); then compound 3; then compound 1.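

In this assay the exchange of 3,5-dimethylbenzyl for 4-fluorophenyl on this aromatic carbon gives a 1.2-fold lower number from compound 2 to compound 4 (0.09 log units; within the scatter) and so leaves the two numbers indistinguishable. The earlier step at this carbon, a 2.6-fold lower number from compound 1 to compound 3 (0.41 log units; beyond the scatter) with furan-2-yl at the chain end, lay beyond the scatter, so this carbon does not respond to every exchange. Nothing available accounts for this difference between the two steps.

On these data alone, it remains open whether an amine or a carboxylic acid on this carbon would keep the number in this range. Also open, as far as these compounds go, is how 4-fluorophenyl behaves with furan-2-yl at the chain end.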